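The compounds below may be only part of what the source reports. "The series", "measured", "known", "first", "only" and "open" are said of these compounds alone.

Working notes on a set of four compounds built on one shared core and followed in a functional assay on the whole organism with Rattus norvegicus as the target; a lower number here means that less compound is needed, a higher number that more compound is needed for the effect.

Compound 1 `CCOCCOC(=O)C(=O)Nc1nc(-c2cc(Cl)no2)cs1` gives 6 mg/kg in this assay. Among the measured compounds shown here, compound 2 `CCOCCOC(=O)C(=O)Nc1nc(-c2cc(C)on2)cs1` gives 1.3 mg/kg in this assay, the lower of the two numbers measured so far. The two cores differ in one place: 5-methyl-1,2-oxazol-3-yl in place of 3-chloro-1,2-oxazol-5-yl on an aromatic carbon. That change produced the step of a 4.6-fold lower number from compound 1 to compound 2 (0.66 log units; beyond the scatter).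

Compound 3 `O=C(O)C(=O)Nc1nc(-c2cc(Cl)no2)cs1` reaches only a limit of this assay, reported as > 30 mg/kg. Compound 3 differs from compound 1 by hydrogen in place of 2-ethoxyethyl on an oxygen next to a carbonyl group, and that change gave the step of an at least 5.0-fold higher number from compound 1 to compound 3 (0.69 log units; beyond the scatter); the size of this step is bounded by the limit of > 30 mg/kg in this assay, at which 1 of the 3 values shown sits, so its true extent is not known.

Compound 4 `Cc1cc(-c2csc(NC(=O)C(=O)O)n2)no1` has not yet been measured. It is built on the core of compound 2 and stands to compound 2 exactly as compound 3 stands to compound 1: hydrogen in place of 2-ethoxyethyl on an oxygen next to a carbonyl group. The place of the change is the same in both pairs, so this is the same change made a second time.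

For compound 4 the step of a 7.7-fold higher number from compound 2 to compound 4 (0.89 log units; beyond the scatter) is expected, placed beside the earlier step of an at least 5.0-fold higher number from compound 1 to compound 3 (0.69 log units; beyond the scatter), because that earlier step an at least 5.0-fold higher number from compound 1 to compound 3 (0.69 log units; beyond the scatter) shows the same change lowering the effect well beyond the scatter. Since compound 2 starts from a lower number than compound 1, compound 4 may still return a number rather than a limit, though a limit remains possible.

Compound 4 is therefore expected to give about 10 mg/kg in this assay, most likely between 4 mg/kg and 30 mg/kg.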

Compound 4, dose for half-maximal effect: 1.7 mg/kg
Beside the measured number, compound 4's estimate is 5.9-fold (0.77 log units) above it; the whole stated range lies above it.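

In this assay, hydrogen in place of 2-ethoxyethyl on an oxygen next to a carbonyl group gives a 1.3-fold higher number from compound 2 to compound 4 (0.12 log units; within the scatter), so on this second core the change leaves the number within the scatter. The same change therefore does not carry over in size from one core to the other, and the core on which it is made matters in this pair of pairs: the same change on two cores in this assay, an at least 5.0-fold higher number (0.69 log units; beyond the scatter) from compound 1 to compound 3 and a 1.3-fold higher number (0.12 log units; within the scatter) from compound 2 to compound 4, at least 3.8-fold (0.58 log units) apart, beyond the scatter of two such steps. Among the compounds shown here, what this does not show is the true size of that gap, the reason for it or any rule for the series, since only two pairs are at hand and the value of compound 3 is a limit of the assay: the limit of > 30 mg/kg in this assay, at which 1 of the 4 values shown sits.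

As far as these compounds go, it remains open whether a shorter chain such as ethyl, or an amide in place of the ester, would follow the pattern of the core of compound 1 or that of the core of compound 2. From the compounds shown here alone, it is also open whether a further core, for instance one carrying a trifluoromethyl group in place of the chlorine or the methyl group, would show a large step or none.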